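The source may hold more compounds than are shown below. What is called first, only, known or untested is meant among the compounds shown, and "the series" means these compounds.

In a functional assay on MIA PaCa-2 cells (Homo sapiens) for inhibition, read by MTT assay (on this read-out lower numbers stand for stronger inhibition and higher numbers for weaker inhibition), the measured compounds stand as follows:
- compound 1 `O=C(Nc1ccccc1)c1cc2cnc(Nc3ccccc3)nc2n1C1CCCC1`: 14000 nM
- compound 2 `O=C(Nc1ccccc1)c1cc2cnc(Nc3ccc(N4CCNCC4)cn3)nc2n1C1CCCC1`: 2800 nM
- compound 3 `O=C(Nc1ccccc1)c1cc2cnc(Nc3ccc(N4CCNCC4)cn3)nc2n1Cc1ccccc1`: 3600 nM

Compound 2 shares the low end of these numbers with one other compound: a 1.3-fold higher number from compound 2 to compound 3 (0.11 log units; within the scatter), while a 5.0-fold lower number from compound 1 to compound 2 (0.70 log units; beyond the scatter). Compound 4 `COc1ccc(NC(=O)c2cc3cnc(Nc4ccc(N5CCNCC5)cn4)nc3n2C2CCCC2)cc1` carries (4-methoxyphenyl)carbamoyl in place of the phenylcarbamoyl of compound 2: methoxy in place of hydrogen on an aromatic carbon. Neither measured step touches this group, since both changes lie elsewhere on the molecule, so neither gives a size or direction for it. No step beyond the scatter is therefore expected in this assay. The expected change is a 1.1-fold higher number from compound 2 to compound 4 (0.03 log units; within the scatter). For compound 4 the estimated value is 3000 nM, with an expected range from 1200 nM to 7500 nM.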

Compound 4, half-maximal inhibitory concentration: 2880 nM
Compound 4: the middle estimate sits 1.0-fold (0.02 log units) above what was measured; measured number inside the range.
By their numbers in this assay, from the lowest: compounds 2, 4 and 3 (each within the scatter of the next); then compound 1.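

In this assay, methoxy in place of hydrogen on an aromatic carbon, para to a large group, gives a 1.0-fold higher number from compound 2 to compound 4 (0.01 log units; within the scatter). For the compounds shown here, this is the first reading at this position, which neither earlier step touched, and with the rest of compound 2 held fixed, 4-methoxyphenyl and phenyl read alike. No evidence is available that bears on this result.

The compounds shown leave open whether an amine or a carboxylic acid on that same aromatic carbon would give a step beyond the scatter. They also leave open whether methoxy there would read alike with benzyl in place of cyclopentyl.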